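The source may hold more compounds than are shown below. What is called first, only, known or untested is meant among the compounds shown, and "the series" means these compounds.

Working notes on the series.

Within the data shown here, compound 2 `CNC(=O)c1cc(C(=O)NC2CCOCC2)n([C@@H](C)c2ccccc2)n1` sits among three measured analogues that share no single-point step between them: compound 1 `CC[C@@H](c1ccccc1)n1nc(C(=O)NC)cc1C(=O)N[C@H]1[C@@H]2C[C@H](O)C[C@@H]21` and compound 3 `CNC(=O)c1cc(C(=O)NC2CC2)cn(Cc2cccc3[nH]ccc23)c1=O`. In an ADME assay for permeability (on this read-out lower numbers stand for lower permeability and higher numbers for higher permeability), compound 2 gives 270 nm/s. In this assay compound 1 gives 230 nm/s, and compound 3 gives 178 nm/s. The three numbers sit close together; the gaps from compound 2 to compound 1 and from compound 2 to compound 3 both fall within the usual scatter of this kind of measurement, so nothing separates them.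

The next compound is compound 4 `CNC(=O)c1cc(C(=O)NC2CC2)n([C@@H](C)c2ccccc2)n1`, not yet measured in this assay. Relative to compound 2 the change is cyclopropyl in place of oxan-4-yl on an amide-type nitrogen, on the amide-type nitrogen whose other neighbour is the carbonyl carbon.

Among the measured compounds shown here, no measured pair in hand isolates this change, so the expectation rests on the closeness of the three numbers. The step expected in this assay, a 1.3-fold higher number from compound 2 to compound 4 (0.11 log units; within the scatter), is small and upward, at the edge of the scatter. For compound 4 the estimated value in this assay is 350 nm/s, with a range from 200 nm/s to 600 nm/s.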

Compound 4, apparent permeability: > 400 nm/s
Compound 4 gave a limit, no number (the forecaster's own chance of this, stated with the estimate: 5%); middle value at least 1.1-fold (0.05 log units) from the limit.
By their numbers in this assay, from the lowest: compounds 3, 1 and 2 (each within the scatter of the next). At a limit, above all of these: compound 4.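

Among these compounds, this pair is the only single-point step, and it gives the first direct reading of the amide-type nitrogen whose other neighbour is the carbonyl carbon. Compound 4 reads > 400 nm/s in this assay, which is a limit of the assay and not a number. Cyclopropyl in place of oxan-4-yl gives an at least 1.4-fold higher number from compound 2 to compound 4 (0.17 log units; that floor lies within the scatter), so the direction is upward but the floor alone does not clear the scatter, and the true size stays unknown at the limit: the limit of > 400 nm/s in this assay, at which 1 of the 4 values shown sits.

The compounds shown do not separate the loss of the ring oxygen from the smaller ring, a question that cyclohexyl on the same nitrogen would address. On these data alone, how an open chain such as isopropyl or a ring carrying an amine, such as piperidin-4-yl, would read at this place also remains open.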